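The compounds below may be only part of what the source reports. "The series", "measured", "known", "first", "only" and "open" are said of these compounds alone.

Measured compounds:
Compound 1, `Cc1nc(SCC(=O)Nc2nc(-c3ccc(Cl)cc3)cs2)n(Nc2ccccc2)c1C`, gives 94100 nM in a functional assay on EKVX cells (Homo sapiens) for antiproliferative activity, read by sulforhodamine B assay, with a stated time of 48 h; on this read-out lower numbers stand for higher toxicity in this test and higher numbers for lower toxicity in this test.
Compound 2, `Cc1ccc(Nn2c(SCC(=O)Nc3nc(-c4ccccc4)cs3)nc(C)c2C)cc1`, gives > 100000 nM in this assay; this is a limit of the assay, not a number.

Going by the values given here, only two compounds have been measured, and compound 1 stands at the single numerical value shown, a weak one. Compound 2 sits at the limit of > 100000 nM in this assay, at which 1 of the 2 values shown sits, and so yields no number at all. Among the compounds with values here, no pair of measured compounds differs in just one place, so no measured step can be drawn from them.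

Compound 3, `COc1ccc(Nn2c(SCC(=O)Nc3nc(-c4ccc(Cl)cc4)cs3)nc(C)c2C)cc1`, has not been measured. It differs from compound 1 in one place: methoxy in place of hydrogen on an aromatic carbon. Within the data shown here, with no measured step to lean on, the expected size of the change is none beyond the usual scatter of this assay. Compound 3 is therefore expected to give about 90000 nM, between 40000 nM and 160000 nM, which would mean an estimated step of a 1.0-fold lower number from compound 1 to compound 3 (0.02 log units; within the scatter). Given that compound 2 stops at the limit (the limit of > 100000 nM in this assay, at which 1 of the 2 values shown sits), compound 3 may also report only a limit.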

Compound 3, concentration lethal to 50% of the cells: > 100000 nM
Compound 3: a limit, no number; the forecaster's own chance of this, stated with the estimate: 45%; middle value at least 1.1-fold (0.04 log units) away from the limit.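

Turning the anilino group into (4-methoxyphenyl)amino is the first change at this ring position that can be read against a measured number, and in this assay it gives an at least 1.0-fold higher number from compound 1 to compound 3 (0.02 log units; that floor lies within the scatter). This step is only a floor, so it shows no sign that methoxy at this position lowers the number, but it cannot say how large the real change is. The new result also shows how little room this series has on this read-out, since most values shown now stop at the same limit and give no number: the limit of > 100000 nM in this assay, at which 2 of the 3 values shown sit.

On these data alone, it remains open whether a different group on this aromatic carbon, such as an amine or a carboxylic acid, would give a clear number rather than another limit. The compounds shown also leave open how methoxy would behave at this position in a compound that starts from a much lower number, where a change in either direction could be measured in full.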